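The source may report more compounds than this note shows. Statements on the series, on what has been measured and on what is new or still open speak of the compounds shown alone.

Working notes on the series. Every measured compound was run in an assay on isolated protein for binding affinity to Adrenergic receptor alpha-1 (Rattus norvegicus), read by radioligand binding; on this read-out higher numbers stand for weaker inhibition and lower numbers for stronger inhibition. Compound 1 `O=C1C2CCCN2C(=O)N1CN1CCN(c2cccc(C(F)(F)F)c2)CC1` reaches only the limit of this assay and returns > 1000 nM. Compound 2 `O=C1C2CCCCN2C(=O)N1CN1CCN(c2cccc(C(F)(F)F)c2)CC1` likewise gives a limit rather than a number, > 1000 nM. Compound 3 `O=C1C2CCCCN2C(=O)N1CCN1CCN(c2ccccc2)CC1` also stops at the limit and gives > 1000 nM. So compound 3 stands nowhere in particular: all three values shown are limits, and the limit of > 1000 nM in this assay, at which 3 of the 3 values shown sit, leaves no ordering among the measured compounds. Within the data shown here, no step between measured compounds can be drawn from these numbers.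

Compound 4 `O=C1C2CCCCN2C(=O)N1CCN1CCN(c2cccc(C(F)(F)F)c2)CC1` has not yet been measured. It differs from compound 3 by trifluoromethyl in place of hydrogen on an aromatic carbon. Compound 1 and compound 2 carry the same trifluoromethyl group and both sit at the limit, so no step beyond the scatter is anticipated. The expected step from compound 3 to compound 4 is a step that the limit leaves unreadable from compound 3 to compound 4. Compound 4 is estimated to come out near 3000 nM in this assay, within 1000 nM to 20000 nM, and most probably it will again be reported only as a limit.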

Compound 4, inhibition constant: > 1000 nM
Compound 4 was reported as a limit; the forecaster's own chance of this, stated with the estimate: 85%; the middle value lies beyond the limit too.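

No step can be read from compound 3 to compound 4, because both values are limits of the assay: the limit of > 1000 nM in this assay, at which 4 of the 4 values shown sit. The compounds shown leave open how strongly any of them binds in this assay, and what trifluoromethyl in place of hydrogen on an aromatic carbon changes.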